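The source may hold more compounds than are shown below. What is called first, only, known or untested is meant among the compounds shown, and "the series" means these compounds.

Measured compounds:
Compound 1, `CCc1cc(C(C)=O)c(O)cc1OCCCC(C)(C)C(=O)O` — 89%
Compound 2, `CCc1cc(C(C)=O)c(O)cc1OCCCCCCSC` — 71%
Compound 3, `CCc1cc(C(C)=O)c(O)cc1OCCCCCCS(C)(=O)=O` — 99%

In an assay on isolated protein for inhibition of leukotriene B4 receptor 1 (Homo sapiens), tested at 10 uM (on this read-out higher numbers stand for more inhibition at the one concentration tested (going by the name of the read-out) and lower numbers for less inhibition), compound 3 stands at the top of the three numbers, though only just: the step of a number 10 percentage points higher from compound 1 to compound 3 (within the scatter) is within the scatter, while a number 28 percentage points higher from compound 2 to compound 3 (beyond the scatter) is beyond it. Compound 4, `CCc1cc(C(C)=O)c(O)cc1OCCCCCCC(=O)O`, differs from compound 3 by carboxy in place of methylsulfonyl on a saturated chain carbon, six bonds along the chain from an oxygen on an aromatic ring. Among the compounds with values here, two measured steps bear on this change. Within the data shown here, compound 1 also carries a carboxy group on its chain, and a number 10 percentage points higher from compound 1 to compound 3 (within the scatter); the exchange to a sulfanyl group, a number 28 percentage points higher from compound 2 to compound 3 (beyond the scatter), is the only change on this chain that went beyond the scatter. A carboxy group is therefore expected to hold the number close to that of compound 3, with a number 9 percentage points lower from compound 3 to compound 4 (within the scatter) expected, so compound 4 is estimated at 90%, between 75% and 99%.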

Compound 4, a percentage reported as inhibition, at one concentration (the size of the read-out at that concentration, not a potency): 87%
The estimate for compound 4 lay 3 percentage points above the measured number; the measured number falls inside the stated range.
By their numbers in this assay, from the lowest: compound 2; then compounds 4, 1 and 3 (each within the scatter of the next, the first and the last beyond it).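

In this assay, carboxy on a saturated chain carbon, six bonds along the chain from an oxygen on an aromatic ring, gives a number distinct from both sulfur groups: a number 12 percentage points lower from compound 3 to compound 4 (beyond the scatter) and a number 16 percentage points higher from compound 2 to compound 4 (beyond the scatter). The two carboxy-bearing chains cannot be told apart, with a number 2 percentage points lower from compound 1 to compound 4 (within the scatter), so 3-carboxypropyl and 1-carboxy-1-methylethyl read alike here. No evidence is available to explain these steps. The compounds shown leave open how an amine or a sulfonamide would read at this place, and whether a longer chain carrying carboxy would hold the number.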